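The source may hold more compounds than are shown below. What is called first, only, known or untested is meant among the compounds shown, and "the series" means these compounds.

Working notes on the series.

Three measured compounds share the core of compound 1 `CCCC(=O)Nc1ccc(S(=O)(=O)Oc2ccccc2I)cc1`, which in a functional assay on M21 cells (Homo sapiens) for antiproliferative activity, read by sulforhodamine B assay, with a stated time of 48 h (on this read-out higher numbers stand for weaker inhibition and lower numbers for stronger inhibition), gives 9000 nM. Compound 2 `CCCCCC(=O)Nc1ccc(S(=O)(=O)Oc2ccccc2I)cc1` gives 11000 nM and compound 3 `O=C(CCCCl)Nc1ccc(S(=O)(=O)Oc2ccccc2I)cc1` gives 7200 nM in this assay. Compound 3 gives the lowest of the three numbers, yet a 1.3-fold lower number from compound 1 to compound 3 (0.10 log units; within the scatter) and a 1.5-fold lower number from compound 2 to compound 3 (0.18 log units; within the scatter) both fall within the scatter, as does a 1.2-fold higher number from compound 1 to compound 2 (0.09 log units; within the scatter); the three numbers therefore cannot be separated.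

Compound 4 `CCNC(=O)Nc1ccc(S(=O)(=O)Oc2ccccc2I)cc1` is not yet measured. Relative to compound 3 it carries ethylamino in place of 3-chloropropyl on a carbonyl carbon. All three measured steps change a saturated chain carbon three bonds along the chain from the carbonyl carbon, and none of them exceeds the scatter. Among the compounds with values here, no measured step changes the group on the carbonyl carbon itself, so the precedent is indirect. Given that every measured variation of the chain left this assay unmoved, the expectation for compound 4 is a step of a 1.1-fold higher number from compound 3 to compound 4 (0.05 log units; within the scatter), that is, no step beyond the scatter. Compound 4 is estimated at 8000 nM, with a range from 3000 nM to 25000 nM.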

Compound 4, half-maximal inhibitory concentration: 5600 nM
Estimate against measurement, compound 4: 1.4-fold (0.15 log units) above, and the stated range covers the measured number.
By their numbers in this assay, from the lowest: compounds 4, 3, 1 and 2 (each within the scatter of the next).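

In this assay the first change made on the carbonyl carbon itself gives a 1.3-fold lower number from compound 3 to compound 4 (0.11 log units; within the scatter) and a 1.6-fold lower number from compound 1 to compound 4 (0.21 log units; within the scatter) and also a 2.0-fold lower number from compound 2 to compound 4 (0.29 log units; within the scatter) for the same exchange of ethylamino against each carbon chain. The insensitivity seen along the chain therefore extends to the group on the carbonyl carbon: ethylamino brings one hydrogen-bond donor where 3-chloropropyl has none, and the number does not move beyond the scatter from any of the three compounds. No supporting measurement is available to interpret this result further.

Going by these compounds, whether a dimethylamino group, a much longer chain such as decyl or a carboxylic acid on the chain end would shift the number beyond the scatter remains open. The compounds shown also vary only this one side of the shared core, so the rest of it remains untested.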